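Removing the ethyl group from compound 3

The source may report more compounds than this note shows. Statements on the series, on what has been measured and on what is new or still open speak of the compounds shown alone.

- Compound 1 `O=C1CC2(CCN(CCC3CCCCC3)CC2)Oc2c1ccc1ccccc21`: 20000 nM
- Compound 2 `OC1CC2(CCNCC2)Oc2c1ccc1ccccc21`: 40000 nM
- Compound 3 `CCN1CCC2(CC1)CC(=O)c1ccc3ccccc3c1O2`: >= 80000 nM (a limit, not a number)

These values come from a physicochemical assay for solubility, read by HPLC, at pH 2; a higher number here means a more soluble compound, a lower number a less soluble compound. Compound 3 has only a limit of the assay, not an exact number: the limit of >= 80000 nM in this assay, at which 1 of the 3 values shown sits.

The next compound, compound 4 `O=C1CC2(CCNCC2)Oc2c1ccc1ccccc21`, has hydrogen in place of ethyl on an amine nitrogen in a ring. Going by the values given here, only one measured step bears on this change: an at least 4.0-fold higher number from compound 1 to compound 3 (0.60 log units; beyond the scatter). That step is beyond the scatter, and it also puts hydrogen in place of a group, though on a saturated chain carbon rather than on the nitrogen itself. Going by these compounds, it ends at a limit, so its full size is unknown. It offers only a loose guide, and a drop is not expected. Compound 4 may well be reported as a limit too. The expected change is a number no higher from compound 3 to compound 4 (the limit leaves the size open), with no step beyond the scatter anticipated. For compound 4 the estimate is 80000 nM, within a range of 40000 nM to 120000 nM.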

Compound 4, solubility: >= 80000 nM
Compound 4: a limit, no number; the forecaster's own chance of this, stated with the estimate: 60%; the middle value sits exactly at the limit.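

In this assay, the earlier step changed the far end of the chain, whereas this one takes the whole 2-cyclohexylethyl group off the amine nitrogen in the ring and leaves hydrogen there, giving an at least 4.0-fold higher number from compound 1 to compound 4 (0.60 log units; beyond the scatter). Going by these compounds, that step ends at a limit, not a number, so it sets only a minimum for this change and its full size remains unknown. The step from compound 3 to compound 4 cannot be read, so ethyl and hydrogen on this nitrogen cannot be ranked, because both compounds sit at the same limit: the limit of >= 80000 nM in this assay, at which 2 of the 4 values shown sit.

On these data alone, the true values of compound 3 and compound 4 stay open, and so does the size of the step between them. Also open, as far as these compounds go, is how a butyl chain or a benzyl group on this nitrogen would read, which would help to show how large a group the nitrogen can carry before the number falls.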